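Swapping the ether-side group on a brominated diphenyl ether core

This account rests on a few compounds, and the source may have more. Where it says the series, first, only, none or still open, it means among the compounds named here.

Of the compounds shown here, three sharing one core have been tested in a functional assay on U-937 cells (Homo sapiens) for cytotoxicity, read by MTT assay, with a stated time of 24 h; a higher number here means a weaker inhibitor, a lower number a stronger inhibitor. Compound 1 `OCCCOc1c(Br)cc(Br)cc1Oc1ccc(Br)cc1Br` gives 32.3 ug/mL. Compound 2 `COc1c(Br)cc(Br)cc1Oc1ccc(Br)cc1Br` gives 34.5 ug/mL. Compound 3 `CCOC(=O)C(C)Oc1c(Br)cc(Br)cc1Oc1ccc(Br)cc1Br` gives 39.5 ug/mL, the highest of the three numbers, though all three sit within the scatter of one another. The steps among them, a 1.1-fold higher number from compound 1 to compound 2 (0.03 log units; within the scatter), a 1.2-fold higher number from compound 1 to compound 3 (0.09 log units; within the scatter) and a 1.1-fold higher number from compound 2 to compound 3 (0.06 log units; within the scatter), each stayed within the scatter.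

Compound 4 `BrCCOc1c(Br)cc(Br)cc1Oc1ccc(Br)cc1Br` is next. Its change from compound 3 is 2-bromoethyl in place of 1-(ethoxycarbonyl)ethyl on an oxygen on an aromatic ring, again at the oxygen on an aromatic ring where compounds 1, 2 and 3 already differ from one another. Those three earlier steps all changed the group on this oxygen without moving the number beyond the scatter, so a similar outcome is expected here, in this assay, with no step beyond the scatter in either direction, a 1.1-fold lower number from compound 3 to compound 4 (0.05 log units; within the scatter).

Compound 4 is therefore estimated at 35 ug/mL in this assay, within a range from 20 ug/mL to 65 ug/mL.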

Compound 4, half-maximal inhibitory concentration: 32.5 ug/mL
Compound 4: middle estimate off by 1.1-fold (0.03 log units), on the high side; low and high end bracket the measured number.
By their numbers in this assay, from the lowest: compounds 1, 4, 2 and 3 (each within the scatter of the next).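

With a bromine now at the end of the chain on this oxygen, the number in this assay still does not leave the scatter: the steps of a 1.2-fold lower number from compound 3 to compound 4 (0.08 log units; within the scatter) and a 1.1-fold lower number from compound 2 to compound 4 (0.03 log units; within the scatter) and a 1.0-fold higher number from compound 1 to compound 4 (0.00 log units; within the scatter) all stay within it. The first of these replaces 1-(ethoxycarbonyl)ethyl, which has a double bond and hydrogen-bond acceptors, with 2-bromoethyl, which has neither, and the last exchanges a chain-end hydroxymethyl for bromo, yet the four compounds cannot be told apart in this assay. Nothing measured here accounts for this sameness.

From the compounds shown here alone, whether an amine or a carboxylic acid on this oxygen, or a much longer chain, would move the number beyond the scatter remains open. So does the effect of changing the shared core itself rather than this group.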